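From Cyclopropyl to Cyclobutyl on the Amide Nitrogen

A few compounds are considered here, and "the series" means these few. Any claim that something is new, unique, unknown or untested is made for them only; others in the source may bear on it.

Of the compounds shown here, two with a shared core have numbers so far in a functional assay on MDA-MB-231 cells (Homo sapiens) for inhibition, read by MTT assay, with a stated time of 48 h; a higher number here means a weaker inhibitor, a lower number a stronger inhibitor. Compound 1 `N#Cc1ccccc1NC(=O)c1[nH]cnc1-c1nc2ccccc2[nH]1` gives 34200 nM, and compound 2 `O=C(NC1CC1)c1[nH]cnc1-c1nc2ccccc2[nH]1` gives 35200 nM. Compound 2 therefore stands level with compound 1, and the two values cannot be told apart.

Compound 3 `O=C(NC1CCC1)c1[nH]cnc1-c1nc2ccccc2[nH]1` has not yet been measured. It carries cyclobutyl in place of cyclopropyl on an amide-type nitrogen. For the measured compounds named here, only one measured step bears on this change: a 1.0-fold higher number from compound 1 to compound 2 (0.01 log units; within the scatter). That step put cyclopropyl in place of 2-cyanophenyl on the same amide-type nitrogen, and it stayed within the scatter. Going by the values given here, one step is thin evidence, and no measured compound yet shows how a change of ring size at this place behaves. Even so, the only exchange seen here left the number where it was, so no shift beyond the scatter is expected in either direction. The expected step is a 1.1-fold lower number from compound 2 to compound 3 (0.03 log units; within the scatter). For compound 3 the estimated value in this assay is 33000 nM, with an expected range of 17000 nM to 60000 nM.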

Compound 3, half-maximal inhibitory concentration: 33800 nM
Compound 3: middle estimate off by 1.0-fold (0.01 log units), on the low side, within the range that was stated.
By their numbers in this assay, from the lowest: compounds 3, 1 and 2 (each within the scatter of the next).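

In this assay, for the compounds shown here, the move from cyclopropyl to cyclobutyl on the amide-type nitrogen gives a 1.0-fold lower number from compound 2 to compound 3 (0.02 log units; within the scatter) and is the first measured step here in which only the ring size of the group at this place differs, a comparison the earlier pair could not offer. The exchange of 2-cyanophenyl for cyclobutyl at the same place gives a 1.0-fold lower number from compound 1 to compound 3 (0.01 log units; within the scatter) and, together with the earlier step, puts all three groups on this nitrogen within the scatter of one another, so that neither the smaller carbon ring, the larger carbon ring nor the 2-cyanophenyl group separates from the others in this series. No measurement is available that would explain why these three compounds read alike.

The compounds shown leave open whether any group on this nitrogen can move the number beyond the scatter, since all three substituents seen so far are rings, and a straight butyl chain, a morpholine ring or a group bearing a carboxylic acid would test that further. They also leave open what a change anywhere on the shared core would do, as every compound here differs only at the amide-type nitrogen.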